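Fluoro in place of chloro on the shared core

The compounds below may be only part of what the source reports. "The series", "measured", "known", "first", "only" and "open" are said of these compounds alone.

Measured in a functional assay on the whole organism with Mus musculus as the target; a higher number here means that more compound is needed for the effect, a lower number that less compound is needed:
Compound 1 `CCNC(=O)/C=C1\CCc2ccc(F)cc21`: 70 mg/kg
Compound 2 `NC(=O)/C=C1\CCc2ccc(Cl)cc21`: 98 mg/kg

Only these two compounds have been measured so far. In this assay compound 2 gives 98 mg/kg, a value within the usual scatter of compound 1 at 70 mg/kg.

Compound 3 `NC(=O)/C=C1\CCc2ccc(F)cc21` has not yet been measured. It comes from compound 2 through a single change, fluoro in place of chloro on an aromatic carbon. The rest of the structure stays the same.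

Among the compounds with values here, no measured pair differs in one place only, so the data do not show directly what this change does. No step beyond the scatter is expected in either direction in this assay, because compound 1 gives 70 mg/kg and compound 2 gives 98 mg/kg, and these two values lie within the scatter of each other. The expected change is a 1.2-fold lower number from compound 2 to compound 3 (0.09 log units; within the scatter), an estimate that stays within the scatter. For compound 3 the estimated value is 80 mg/kg, with an expected range from 40 mg/kg to 160 mg/kg.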

Compound 3, dose for half-maximal effect: 56 mg/kg
Estimate against measurement, compound 3: 1.4-fold (0.15 log units) above; the measured number falls inside the stated range.
By their numbers in this assay, from the lowest: compounds 3, 1 and 2 (each within the scatter of the next).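

With this result, the change of chloro to fluoro on the aromatic carbon can be read directly in this assay, where fluoro in place of chloro gives a 1.8-fold lower number from compound 2 to compound 3 (0.24 log units; within the scatter), so this assay does not separate the two halogens at this position, meta to a fused ring and para to a fused ring. Within the data shown here, the same result also gives the first direct reading at the amide-type nitrogen, where hydrogen in place of ethyl gives a 1.3-fold lower number from compound 1 to compound 3 (0.10 log units; within the scatter), so on the fluoro-bearing core the ethyl group and the hydrogen cannot be told apart either. No other measurement on these compounds bears on this result.

The compounds shown leave open whether this aromatic carbon tolerates groups other than these two halogens, such as a methoxy group, a nitrile or trifluoromethyl, or plain hydrogen. They also leave open whether a longer chain or a ring on the amide-type nitrogen, or a carboxylic acid in place of the amide, would stay within the scatter of these values in this assay.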